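The source may report more compounds than this note shows. Statements on the series, on what has been measured and on what is new or still open speak of the compounds shown alone.

Measured compounds

Compound 1, `COc1cc(NC(C)CCCNC(=O)NNC(=O)Nc2cc(C(F)(F)F)cc(C(F)(F)F)c2)c2ncccc2c1`: 22000 nM
Compound 2, `COc1cc(NC(C)CCCNC(=O)Nc2ccc(C(F)(F)F)cc2)c2ncccc2c1`: 20000 nM
Compound 3, `COc1cc(NC(C)CCCNC(=O)Nc2ccc(O)cc2)c2ncccc2c1`: 21000 nM

All three numbers come from a functional assay on MOLT-4 cells (Homo sapiens) for inhibition, read by MTT assay, with a stated time of 72 h; a lower number here means a stronger inhibitor, a higher number a weaker inhibitor. The three values lie within the scatter of one another, so compound 1 cannot be set apart from compound 2 or compound 3 on these numbers; it simply shares their level.

The unmeasured compound 4, `COc1cc(NC(C)CCCNC(=O)NNC(=O)Nc2cccc(C(F)(F)F)c2)c2ncccc2c1`, is reached from compound 1 by one change, (hydrogen in place of trifluoromethyl on an aromatic carbon).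

Among the measured compounds shown here, only one measured step bears on a change at an aromatic carbon of this kind: a 1.1-fold higher number from compound 2 to compound 3 (0.02 log units; within the scatter), in which one substituent on the aryl ring was exchanged for another without a shift beyond the scatter. For the measured compounds named here, there is no measured step in which a trifluoromethyl is taken away and replaced by hydrogen, and compound 1 and compound 4 share the rest of their structure. Given that the one related exchange left the number unchanged, the expected step in this assay from compound 1 to compound 4 is none beyond the scatter, and the step of no change at the digits printed from compound 1 to compound 4 (within the scatter) is estimated accordingly. Compound 4 is therefore expected to give about 22000 nM, within a range from 10000 nM to 48000 nM.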

Compound 4, half-maximal inhibitory concentration: 36000 nM
Compound 4: middle estimate off by 1.6-fold (0.21 log units), on the low side, within the range that was stated.
By their numbers in this assay, from the lowest: compounds 2, 3, 1 and 4 (each within the scatter of the next).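

In this assay, removing one trifluoromethyl and putting hydrogen on that aromatic carbon gives a 1.6-fold higher number from compound 1 to compound 4 (0.21 log units; within the scatter). Among the compounds shown here, this is the first direct reading at this position, on an aromatic carbon meta to a large group and meta to a trifluoromethyl group; the earlier compounds offered only a 1.1-fold higher number from compound 2 to compound 3 (0.02 log units; within the scatter), an exchange on a different aryl ring with a different linking chain, and now this removal of a trifluoromethyl also stays inside the scatter. No measurement is at hand that would account for the number at this position, or for the flat level of all four compounds.

On these data alone, what stays open is whether any group at this position can move the number beyond the scatter, and an amine, a carboxylic acid or a methoxy group on this carbon would each put that to the test, as would hydrogen in place of the remaining trifluoromethyl. Also open, as far as these compounds go, is whether a change elsewhere, such as a longer chain between the shared core and the urea-bearing end, would shift the number in this assay when changes on the aryl ring have not.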